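The source may hold more compounds than are shown below. What is called first, only, known or untested is meant among the compounds shown, and "the series" means these compounds.

Compound 1 `COc1ccc(CCCN2CCC(COCc3ccc(Cl)cc3)CC2)cc1`: 500 nM in a functional assay on cells (T-cell line, Homo sapiens) for inhibition; on this read-out higher numbers stand for weaker inhibition and lower numbers for stronger inhibition.
Compound 2 `Clc1ccccc1CCCN1CCC(COC(c2ccccc2)c2ccccc2)CC1`: 800 nM in this assay.

Of the two numbers, that of compound 2 is the higher, yet its gap to compound 1 lies within the scatter, so the two are not distinguished. Compound 3 `CCCCCCCN1CCC(COC(c2ccccc2)c2ccccc2)CC1` differs from compound 2 in one place: butyl in place of 2-chlorophenyl on a saturated chain carbon, three bonds along the chain from an amine nitrogen in a ring. Among the compounds with values here, no measured pair shows this change, so the expectation rests on the change alone. In this assay a modest step towards weaker inhibition is expected, a 1.9-fold higher number from compound 2 to compound 3 (0.27 log units; within the scatter). Compound 3 is estimated at 1500 nM, within a range from 500 nM to 5000 nM.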

Compound 3, half-maximal inhibitory concentration: 500 nM
Compound 3: middle estimate off by 3.0-fold (0.48 log units), on the high side; the range from low to high includes it.
By their numbers in this assay, from the lowest: compounds 1, 3 and 2 (each within the scatter of the next).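

In this assay, the step on the shared core is a 1.6-fold lower number from compound 2 to compound 3 (0.20 log units; within the scatter). At this place on the chain, then, the 2-chlorophenyl group can give way to butyl, which has no ring and no chlorine, without a difference that can be told from the scatter. Nothing at hand explains this tolerance.

The compounds shown leave open how far it extends: whether a shorter chain, a longer chain, or an amine or carboxylic acid in the same place would keep inhibition in this range.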